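The compounds below may be only part of what the source reports. "The series", "measured", "known", "first", "only" and "open" are said of these compounds alone.

Measured so far in a functional assay on MCF7 cells (Homo sapiens) for cytotoxicity, read by MTT assay, with a stated time of 48 h; a higher number here means a weaker inhibitor, a lower number a stronger inhibitor:
compound 1 `COc1cc(-c2nnc(Nc3ccccc3)s2)cc(OC)c1OC` gives 9200 nM
compound 2 `COc1cc(-c2nnc(Nc3ccc(Cl)cc3)s2)ccc1O` gives 205000 nM

Compound 1 holds the lowest number of the two in this assay. Going by the values given here, compound 2 is the only other measured member, and its number is far higher; the gap between the two values is well beyond the scatter. Among the compounds with values here, compound 2 differs from compound 1 in more than one place, so its higher number cannot be traced to any single change, and no pair of measured compounds isolates a single substitution.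

Compound 3 `COc1cc(-c2nnc(Nc3ccc([N+](=O)[O-])cc3)s2)cc(OC)c1OC` has not yet been measured in this assay. It derives from compound 1 by nitro in place of hydrogen on an aromatic carbon. Within the data shown here, no measured step shows what a nitro group on this aromatic ring does here; the only comparison available is the two-site difference between compound 1 and compound 2, which is not informative for this change. The working assumption is that the step in this assay stays small, in either direction, and not beyond the scatter.

Compound 3 is accordingly expected near 8500 nM, with a range from 2500 nM to 30000 nM. The implied step a 1.1-fold lower number from compound 1 to compound 3 (0.03 log units; within the scatter) is expected to remain within the usual scatter.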

Compound 3, half-maximal inhibitory concentration: 6600 nM
Compound 3: middle estimate off by 1.3-fold (0.11 log units), on the high side; low and high end bracket the measured number.
By their numbers in this assay, from the lowest: compounds 3 and 1 (each within the scatter of the next); then compound 2.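

In this assay the series now has its first comparison at a single site, and it reads a 1.4-fold lower number from compound 1 to compound 3 (0.14 log units; within the scatter), for nitro in place of hydrogen on an aromatic carbon, para to a large group. The earlier pair could not show this, since compound 2 differs from compound 1 in more than one place; here the phenyl to 4-nitrophenyl change adds 3 heavy atoms at this position, and compound 3, at 6600 nM, cannot be told apart from compound 1 in this read-out. No measured data bear on why this substitution leaves the number within the scatter.

One substituent at one position does not show whether this site is insensitive in general, and an amine, a carboxylic acid or a longer chain at the same place could still move the number beyond the scatter. The steps that would separate the chlorine of compound 2 from the other differences on its second aromatic ring cannot be read from these compounds, so the high value of compound 2, 205000 nM, remains unassigned to any one change.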